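A few compounds are considered here, and "the series" means these few. Any claim that something is new, unique, unknown or untested is made for them only; others in the source may bear on it.

Measured compounds and their values:

Compound 1, `O=Cc1ccccc1OCc1cn(CCCOc2ccc3ccc(=O)oc3c2)nn1`, in an ADME assay on HEK-293T cells (Homo sapiens) for cytotoxicity, read by MTT assay, with a stated time of 24 h; a lower number here means a stronger inhibitor, a higher number a weaker inhibitor: 13700 nM
Compound 2, `CCN(CC)c1ccc(C=O)c(OCc2cn(CCCOc3ccc4ccc(=O)oc4c3)nn2)c1`, in this assay: 19200 nM
Compound 3, `NS(=O)(=O)c1ccc(C/N=C/c2ccccc2OCc2cn(CCCOc3ccc4ccc(=O)oc4c3)nn2)cc1`, in this assay: 13900 nM

The three numbers lie within the scatter of one another, so among these three compounds no order in this assay can be drawn. Compound 2 differs from compound 1 by diethylamino in place of hydrogen on an aromatic carbon. That step came out as a 1.4-fold higher number from compound 1 to compound 2 (0.15 log units; within the scatter). Compound 3 has a different core from compound 1, and the difference between the two cores is not broken down here.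

Compound 4, `CCN(CC)c1ccc(/C=N/Cc2ccc(S(N)(=O)=O)cc2)c(OCc2cn(CCCOc3ccc4ccc(=O)oc4c3)nn2)c1`, has not yet been measured in this assay. It differs from compound 3 by diethylamino in place of hydrogen on an aromatic carbon. Among the measured compounds shown here, this is the same kind of change as the one from compound 1 to compound 2, though not the same: in compound 2 the entering group sits para to a formyl group, whereas in compound 4 it sits para to a large group. For the measured compounds named here, the single earlier instance of this change left the number essentially unchanged, and the expectation for compound 4 rests on that one step from compound 1 to compound 2. The resulting step is estimated at a 1.3-fold higher number from compound 3 to compound 4 (0.11 log units; within the scatter). Compound 4 is therefore expected to give about 18000 nM in this assay, with the estimate expected to fall between 9000 nM and 36000 nM.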

Compound 4, half-maximal inhibitory concentration: 29500 nM
The estimate for compound 4 lay 1.6-fold (0.21 log units) below the measured number, within the range that was stated.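

In this assay, diethylamino in place of hydrogen on an aromatic carbon gave a 2.1-fold higher number from compound 3 to compound 4 (0.33 log units; beyond the scatter), a modest step. Set beside the only earlier instance of this change, the new step cannot be told apart from it, even though one step lies within the scatter and the other beyond it: the same change on two cores in this assay, a 1.4-fold higher number (0.15 log units; within the scatter) from compound 1 to compound 2 and a 2.1-fold higher number (0.33 log units; beyond the scatter) from compound 3 to compound 4, 1.5-fold (0.18 log units) apart, within the scatter of two such steps. Among the compounds shown here, this shows that nothing here marks the change as behaving differently on these two cores, but with only two steps, it does not show that a step of this size would hold on a further core, nor what in the structures sets its size.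

The compounds shown leave open whether a different amine in the same place, such as dimethylamino or a morpholine, would give a step of similar size, and whether a group that is not an amine at all, such as methoxy or a halogen, would do the same. Also open, as far as these compounds go, is whether the change would carry over to compounds in which a carboxylic acid takes the place of the sulfonamide, or in which a longer chain links the two parts of the molecule.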